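The compounds below may be only part of what the source reports. "The series", "measured", "known", "first", "only" and "open" are said of these compounds alone.

Measured compounds:
compound 1, `O=C(/C=C/c1ccc(N2CCCC2)cc1)c1ccc([N+](=O)[O-])cc1`, > 25000 nM
compound 2, `O=C(/C=C/c1ccc(F)cc1)c1ccc(O)cc1O`, 9430 nM

In a functional assay on SNU-638 cells (Homo sapiens) for cytotoxicity, read by MTT assay (a lower number here means a stronger inhibitor, a higher number a weaker inhibitor), compound 1 gives only a limit, > 25000 nM. In this assay, going by the values given here, compound 2 gives 9430 nM, the only plain number among the two values. The other value, that of compound 1, is the limit (the limit of > 25000 nM in this assay, at which 1 of the 2 values shown sits). Compound 3, `O=C(/C=C/c1ccc(N2CCCC2)cc1)c1ccc(O)cc1O`, has not been tested. It differs from compound 2 by pyrrolidin-1-yl in place of fluoro on an aromatic carbon, on an aromatic carbon of a six-membered aromatic ring of carbon only, para to a large group. Among the compounds with values here, with no measured step of this kind to lean on, the step from compound 2 to compound 3 is expected to be small, a 1.2-fold lower number from compound 2 to compound 3 (0.07 log units; within the scatter), within the scatter. Compound 3 is therefore estimated at 8000 nM, between 2000 nM and 25000 nM.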

Compound 3, half-maximal inhibitory concentration: 5770 nM
For compound 3 the middle estimate is 1.4-fold (0.14 log units) above the measured one; measured number inside the range.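

In this assay, pyrrolidin-1-yl in place of fluoro on this aromatic carbon, para to a large group, gives a 1.6-fold lower number from compound 2 to compound 3 (0.21 log units; within the scatter) and so no real change. At this position, a single fluorine and a group carrying a five-membered non-aromatic ring thus give values within the scatter of each other. Nothing measured here accounts for this step.

Going by these compounds, it remains open whether an open-chain amine such as dimethylamino, or a carboxylic acid, on this carbon would also leave the number within the scatter. On these data alone, the effect of a bare hydrogen there is equally open.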